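Swapping 4-nitrophenyl for 2-chlorophenyl on the sulfonyl sulfur

A few compounds are considered here, and "the series" means these few. Any claim that something is new, unique, unknown or untested is made for them only; others in the source may bear on it.

Within the data shown here, in an assay on MDA-MB-231 cells for displacement of a labelled ligand from C-X-C chemokine receptor type 4 (Homo sapiens), read by fluorescence and microscopy, with stated times of 10 min and 30 min (a lower number here means that less compound is needed, a higher number that more compound is needed for the effect), compound 2 `COc1ccccc1C(=O)NCc1ccc(CNS(=O)(=O)c2ccc([N+](=O)[O-])cc2)cc1` gives 100 nM, the higher of the two numbers measured so far; its nearest neighbour is compound 1 `COc1ccccc1C(=O)NCc1ccc(CNS(=O)(=O)c2ccccc2F)cc1`, which gives 1 nM. Compound 3 `COc1ccccc1C(=O)NCc1ccc(CNS(=O)(=O)c2ccccc2Cl)cc1` differs from compound 2 by 2-chlorophenyl in place of 4-nitrophenyl on a sulfonyl sulfur. Among the measured compounds shown here, the one measured step bearing on this change is a 100-fold higher number from compound 1 to compound 2 (2.00 log units; beyond the scatter), which ran the opposite way, from 2-fluorophenyl to 4-nitrophenyl. Compound 3 carries a 2-chlorophenyl, resembling the 2-fluorophenyl of compound 1 rather than the 4-nitrophenyl of compound 2, so a large step back down is expected: a 50-fold lower number from compound 2 to compound 3 (1.70 log units; beyond the scatter). Compound 3 is therefore estimated at 2 nM, with a range from 0.5 nM to 10 nM.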

Compound 3, effective concentration (reported as EC, without a stated level of effect): 100 nM
Estimate against measurement, compound 3: 50-fold (1.70 log units) below, outside the stated range (above it).
By their numbers in this assay, from the lowest: compound 1; then compounds 2 and 3 (each within the scatter of the next).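

In this assay, 2-chlorophenyl in place of 4-nitrophenyl on the sulfonyl sulfur moves nothing (no change at the digits printed from compound 2 to compound 3 (within the scatter)), so the high number of compound 2 does not belong to the 4-nitrophenyl alone. The decisive change is smaller: chloro in place of fluoro on an aromatic carbon is enough for the whole gap (a 100-fold higher number from compound 1 to compound 3 (2.00 log units; beyond the scatter)), leaving compound 1, with its 2-fluorophenyl, alone at the low number. No measurement shown explains this. On these data alone, whether a plain phenyl, a methoxyphenyl or an aminophenyl on the sulfonyl sulfur would stand with compound 1 or with compounds 2 and 3 remains open.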